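The source may hold more compounds than are shown below. What is called first, only, known or untested is meant among the compounds shown, and "the series" means these compounds.

The compounds measured so far:

Compound 1 `Cc1ccc2c(NCc3ccc(NC(=O)C4CCN(Cc5ccccc5)CC4)cc3)nc(N3CCCCCC3)nc2c1` — in a functional assay on SV5A8 cells (Homo sapiens) for cytotoxicity (a higher number here means a weaker inhibitor, a lower number a stronger inhibitor), compound 1 gives > 6880 nM, which is a limit of the assay and not a number.
Compound 2 `Cc1ccc2c(NCc3ccc(NC(=O)C4CCN(Cc5ccccc5)CC4)cc3)nc(N3CCN[C@@H](C)C3)nc2c1` — compound 2 gives > 8860 nM, again a limit rather than a number.
Compound 3 `Cc1ccc2c(NCc3ccc(NC(=O)C4CCN(Cc5ncc[nH]5)CC4)cc3)nc(N(C)C)nc2c1` — compound 3 gives > 20000 nM, also a limit.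

Compound 2 therefore stands nowhere in particular on the numbers shown: its value is a limit, and the two further values are limits as well (the limit of > 20000 nM in this assay, at which 1 of the 3 values shown sits, (the limit of > 6880 nM in this assay, at which 1 of the 3 values shown sits), (the limit of > 8860 nM in this assay, at which 1 of the 3 values shown sits)). The one step that joins two of these compounds, a step that the two limits leave unreadable from compound 1 to compound 2, cannot be read in size or direction.

Compound 4 `Cc1ccc2c(NCc3ccc(NC(=O)C4CCN(Cc5ccccc5)CC4)cc3)nc(N(C)CCCN(C)C)nc2c1` differs from compound 2 by (3-(dimethylamino)propyl)(methyl)amino in place of 3-methylpiperazin-1-yl on an aromatic carbon. Among the measured compounds shown here, no measured step bears on this change, and the only step available is unreadable. The account therefore expects compound 4 to sit near the limits of the other three, so that a step that the limit leaves unreadable from compound 2 to compound 4 is estimated as no step beyond the scatter, with a fair chance that only a limit is again reported. For compound 4 the estimate in this assay is 15000 nM, expected to lie between 4000 nM and 50000 nM.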

Compound 4, half-maximal inhibitory concentration: > 8620 nM
Compound 4 gave a limit, no number (the forecaster's own chance of this, stated with the estimate: 75%); the middle value lies beyond the limit too.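

Compound 4 gives > 8620 nM, which is a limit and not a number. The steps from compound 1 and compound 2 to compound 4 cannot be read. The compounds shown leave open how strongly any of them acts in this assay, and whether exchanging the group between two ring nitrogen atoms changes that at all.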